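A few compounds are considered here, and "the series" means these few. Any claim that something is new, unique, unknown or untested is made for them only; others in the source may bear on it.

The shared core of these compounds is shown by compound 3 `Cc1ccc(C(=O)NCC2(C(F)(F)F)OC(=O)Nc3ccc(Cl)cc32)cc1`, which in an assay for inhibition of very long chain fatty acid elongase 6 (Homo sapiens) (a lower number here means a stronger inhibitor, a higher number a weaker inhibitor), gives 38 nM, the lowest of the three numbers recorded. Compound 2 `O=C1Nc2ccc(Cl)cc2C(CNC(=O)c2cccc(F)c2)(C(F)(F)F)O1` carries a 3-fluorophenyl on the same carbonyl carbon and in this assay gives 261 nM. Among the compounds with values here, compound 1 `O=C1Nc2ccc(-n3cncn3)cc2C(CNC(=O)c2ccc(F)cc2)(C(F)(F)F)O1` differs from compound 2 in two places at once, and in this assay compound 1 gives 572 nM; no single step connects it to compound 3.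

Compound 4 `Cc1ccccc1C(=O)NCC1(C(F)(F)F)OC(=O)Nc2ccc(Cl)cc21` has not yet been measured. It differs from compound 3 by 2-methylphenyl in place of 4-methylphenyl on a carbonyl carbon: the same atoms, joined differently. Within the data shown here, the only measured step that bears on this place is a 6.9-fold lower number from compound 2 to compound 3 (0.84 log units; beyond the scatter), which shows that the group on the carbonyl carbon can move the number well beyond the scatter. Among the measured compounds shown here, no measured pair shows what moving a methyl from one position of the phenyl to another does, so the direction is uncertain. A step of similar size in either direction is possible; on balance a somewhat weaker result is expected, as a 3.2-fold higher number from compound 3 to compound 4 (0.50 log units; beyond the scatter). Compound 4 is therefore estimated at 120 nM, with a range from 35 nM to 400 nM.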

Compound 4, half-maximal inhibitory concentration: 971 nM
The estimate for compound 4 lay 8.1-fold (0.91 log units) below the measured number, and the stated range ends below it.
By their numbers in this assay, from the lowest: compound 3; then compound 2; then compounds 1 and 4 (each within the scatter of the next).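

Moving the methyl around the phenyl ring, with nothing else changed, gives a 26-fold higher number from compound 3 to compound 4 (1.41 log units; beyond the scatter) in this assay, which is larger than the step that exchanged one substituted phenyl for another, a 6.9-fold lower number from compound 2 to compound 3 (0.84 log units; beyond the scatter). The 4-methylphenyl and 2-methylphenyl groups match in every count computed for them, so this position responds to how the group's atoms are arranged, not only to which atoms it contains. Having a methyl on this phenyl therefore does not guarantee a low number: the comparison with the 3-fluorophenyl group gives a 3.7-fold higher number from compound 2 to compound 4 (0.57 log units; beyond the scatter), so the better of the two methylphenyl groups lies on one side of the 3-fluorophenyl group and the worse on the other.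

No measurement shown explains why the two methylphenyl groups differ so sharply. The compounds shown leave open how an unsubstituted phenyl, a pyridine ring or a larger naphthyl ring would behave on this carbonyl carbon, and whether the same methyl move would have a similar effect on the core of compound 1.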